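Removing the chloro group from compound 1

This account rests on a few compounds, and the source may have more. Where it says the series, first, only, none or still open, it means among the compounds named here.

Compound 1 `COc1ccc(CNc2cc(OC)c(OC)c(OC)c2)cc1Cl` gives 47800 nM
Compound 2 `C/C=C/C(=O)N(Cc1ccc(OC)c(OC)c1)c1cc(OC)c(OC)c(OC)c1` gives 39100 nM
Compound 3 `CC/C=C/C(=O)N(Cc1ccc(OC)c(O)c1)c1cc(OC)c(OC)c(OC)c1` gives 72 nM

All three values come from a functional assay on KYSE-450 cells (Homo sapiens) for inhibition, read by MTT assay, with a stated time of 48 h; a higher number here means a weaker inhibitor, a lower number a stronger inhibitor. Compound 1 lies within the scatter of compound 2 and far beyond the scatter above compound 3. Compound 4 `COc1ccc(CNc2cc(OC)c(OC)c(OC)c2)cc1` carries one change hydrogen in place of chloro on an aromatic carbon with hydrogen in place of chloro on an aromatic carbon. Going by the values given here, no measured pair isolates this change. Among the compounds with values here, the one low value belongs to compound 3 at 72 nM and that compound differs from compound 1 in several places. In this assay no step beyond the scatter is expected in either direction. The estimated step is a 1.6-fold lower number from compound 1 to compound 4 (0.20 log units; within the scatter) for now. Compound 4 is expected near 30000 nM with an estimated range from 9000 nM to 80000 nM at this stage.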

Compound 4, half-maximal inhibitory concentration: 4890 nM
Compound 4: middle estimate off by 6.1-fold (0.79 log units), on the high side, outside the stated range (below it).
By their numbers in this assay, from the lowest: compound 3; then compound 4; then compounds 2 and 1 (each within the scatter of the next).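

In this assay the chloro group ortho to a methoxy group is not a silent passenger: hydrogen in its place gives a 9.8-fold lower number from compound 1 to compound 4 (0.99 log units; beyond the scatter) and that step lies beyond the scatter. Going by these compounds alone, it is the first effect read at a single position, as compound 3 differs from compound 1 in several places. No measurement shown accounts for the step.

Still open, as far as these compounds go, is whether fluoro, bromo or methyl at this carbon would track compound 1 or compound 4. Whether the same change carries the same step in amides such as compound 2 is also unknown.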